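Trimming the chain on nitrogen from butyl to ethyl

The compounds below may be only part of what the source reports. "The series", "measured", "known", "first", "only" and "open" are said of these compounds alone.

Compound 3 `CCCCn1cc(C(=O)OCC)c(=O)c2ccc(Cl)cc21` has the higher of the two plain numbers in a functional assay on RKO cells (Homo sapiens) for cytotoxicity, read by MTT assay, with a stated time of 24 h; a lower number here means a stronger inhibitor, a higher number a weaker inhibitor: compound 3 gives 45200 nM. Compound 1 `CCOC(=O)c1cn(CCCc2ccccc2)c2cc(Cl)ccc2c1=O` gives 9860 nM in this assay. Compound 2 `CCOC(=O)c1cn(C)c2cc(Cl)ccc2c1=O` reaches only a limit of this assay, > 50000 nM. Compound 4 `CCOC(=O)c1cn(CC)c2cc(Cl)ccc2c1=O` differs from compound 3 by hydrogen in place of ethyl on a saturated chain carbon, two bonds along the chain from an aromatic nitrogen. The step that bears on it is an at least 1.1-fold lower number from compound 2 to compound 3 (0.04 log units; that floor lies within the scatter), which shows that removing chain from the nitrogen gains nothing; an at least 5.0-fold higher number from compound 1 to compound 2 (0.70 log units; beyond the scatter) and a 4.6-fold higher number from compound 1 to compound 3 (0.66 log units; beyond the scatter) point the same way, towards weaker inhibition as the chain shrinks. Compound 4 is therefore expected to sit at or near the limit, with a 1.3-fold higher number from compound 3 to compound 4 (0.12 log units; within the scatter) as the estimated step, giving an estimate for compound 4 of 60000 nM, within 30000 nM to 150000 nM.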

Compound 4, half-maximal inhibitory concentration: > 50000 nM
Compound 4 gave a limit, no number; the forecaster's own chance of this, stated with the estimate: 55%; the middle value lies beyond the limit too.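

In this assay, trimming butyl to ethyl gives an at least 1.1-fold higher number from compound 3 to compound 4 (0.04 log units; that floor lies within the scatter), so this change shows no readable loss at this position. Against the longer chain carrying phenyl, the change gives an at least 5.0-fold higher number from compound 1 to compound 4 (0.70 log units; beyond the scatter), which places compound 4 with the short chains. The value of compound 4 is a limit, not a number, and the step to it from compound 2 cannot be read: the limit of > 50000 nM in this assay, at which 2 of the 4 values shown sit.

Going by these compounds, whether the short chains differ at all remains open. So does whether an amine or a carboxylic acid in place of ethyl would bring a measurable number in this assay.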